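Methylating the triazole of an inactive aspartyl ketone

This account rests on a few compounds, and the source may have more. Where it says the series, first, only, none or still open, it means among the compounds named here.

Compound 1 `COC(=O)c1cc(OCC(=O)[C@H](CC(=O)O)NC(=O)[C@@H](NC(=O)COc2cccc3ccccc23)C(C)C)no1` gives 71000 nM in a functional assay on Jurkat cells (Homo sapiens) for inhibition; a lower number here means a stronger inhibitor, a higher number a weaker inhibitor.
Compound 2 `CC(C)[C@H](NC(=O)COc1cccc2ccccc12)C(=O)N[C@@H](CC(=O)O)C(=O)CSc1nc[nH]n1` reaches only the limit > 200000 nM in this assay.

Compound 2 therefore stands at the weak end of the two measured compounds; its value is a limit of this assay, not a number (the limit of > 200000 nM in this assay, at which 1 of the 2 values shown sits). Compound 3 `CC(C)[C@H](NC(=O)COc1cccc2ccccc12)C(=O)N[C@@H](CC(=O)O)C(=O)CSc1nncn1C` differs from compound 2 by 4-methyl-4H-1,2,4-triazol-3-yl in place of 1H-1,2,4-triazol-3-yl on a sulfur. Among the measured compounds shown here, the only measured step, an at least 2.8-fold higher number from compound 1 to compound 2 (0.44 log units; beyond the scatter), concerns a different part of the molecule and does not bear on this methylation. No change beyond the scatter is therefore expected for a step that the limit leaves unreadable from compound 2 to compound 3. Compound 3 is estimated at 300000 nM, between 100000 nM and 1000000 nM, most likely again reported only as a limit.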

Compound 3, half-maximal inhibitory concentration: > 200000 nM
Compound 3: no number, only a limit (the forecaster's own chance of this, stated with the estimate: 70%); the middle value does not contradict the limit.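

In this assay, compound 3 also gives only a limit, so the step between the two triazoles cannot be read, and methylation brings no measurable value. Exchanging (5-(methoxycarbonyl)-1,2-oxazol-3-yl)oxy for (4-methyl-4H-1,2,4-triazol-3-yl)sulfanyl gives an at least 2.8-fold higher number from compound 1 to compound 3 (0.44 log units; beyond the scatter), matching what the unmethylated triazole showed. Both triazole compounds now rest at the same ceiling: the limit of > 200000 nM in this assay, at which 2 of the 3 values shown sit.

The compounds shown leave open how far either triazole lies beyond that limit. They also leave open whether an aminomethyl group or a carboxylic acid in place of the methyl would yield a readable number.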